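The source may report more compounds than this note shows. Statements on the series, on what has been measured and on what is new or still open speak of the compounds shown alone.

Compound 1 `CC(C)[C@H]1CC[C@@]2(CO2)[C@H]2C(=O)OCC(C(=O)OCc3ccc(-c4ccc([N+](=O)[O-])cc4)o3)=C[C@H]12` holds the lowest of the two numbers in this set. In a functional assay on A-375 cells (Homo sapiens) for inhibition, with a stated time of 72 h (on this read-out lower numbers stand for stronger inhibition and higher numbers for weaker inhibition), compound 1 gives 1640 nM. The nearest number belongs to compound 3 `CNC(=O)C1=C[C@@H]2[C@@H](C(C)C)CC[C@@]3(CO3)[C@H]2C(=O)OC1`, which gives 4150 nM in this assay, a gap beyond the usual scatter of repeated measurements. Compound 2 `CC(C)[C@H]1CC[C@@](O)(CO)[C@H]2C(=O)OCC(C(=O)O)=C[C@H]12` reaches only a limit of this assay, > 32000 nM, and so supplies no number at all. Compound 4 `CC(C)[C@H]1CC[C@@]2(CO2)[C@H]2C(=O)OCC(C(=O)OCc3ccc(-c4ccccc4)o3)=C[C@H]12` has not yet been measured; it differs from compound 1 by hydrogen in place of nitro on an aromatic carbon. Within the data shown here, no measured pair in this set shows that change, so its effect is open; a step of no more than the usual scatter is expected here, in either direction. The expected step is a 1.5-fold higher number from compound 1 to compound 4 (0.18 log units; within the scatter). Compound 4 is therefore estimated at 2500 nM, within a range from 800 nM to 8000 nM.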

Compound 4, half-maximal inhibitory concentration: 1310 nM
Estimate against measurement, compound 4: 1.9-fold (0.28 log units) above; the range from low to high includes it.
By their numbers in this assay, from the lowest: compounds 4 and 1 (each within the scatter of the next); then compound 3. At a limit, above all of these: compound 2.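

Going from 4-nitrophenyl to phenyl gives a 1.3-fold lower number from compound 1 to compound 4 (0.10 log units; within the scatter) in this assay. Among these compounds, this is the first direct look at this place on the aromatic ring, and it shows that the number for compound 1 does not depend on the nitro group: all three of its heavy atoms can go without a change beyond the scatter. Nothing in the data shown bears on why the number holds.

The compounds shown leave open whether an amine or a carboxylic acid at this same place would leave the number equally undisturbed. They also leave open whether the phenyl ring itself is needed.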